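The source may report more compounds than this note shows. Statements on the series, on what has been measured and on what is new or still open speak of the compounds shown alone.

Measured compounds and their values:

Compound 1, `ClCc1cccc(Cn2cnc3c(Cl)ncnc32)c1`, in a functional assay on OVCAR-8 cells (Homo sapiens) for cytotoxicity, read by sulforhodamine B assay, with a stated time of 48 h (on this read-out lower numbers stand for stronger inhibition of growth and higher numbers for weaker inhibition of growth), gives 21900 nM.
Compound 2, `ClCc1cccc(Cn2cnc3c(Cl)nc(Cl)nc32)c1`, in this assay gives 1820 nM.
Compound 3, `ClCc1ccccc1Cn1cnc2ncnc(Cl)c21`, in this assay gives 2750 nM.

Compound 1 and compound 2 differ in one place: chloro in place of hydrogen on an aromatic carbon. This single change gives a 12-fold lower number from compound 1 to compound 2 (1.08 log units; beyond the scatter), a step that is beyond the scatter. Compound 3 shares its atoms with compound 1 but has them joined differently; the difference between the two cores is not broken down here. In this assay compound 3 gives a number close to that of compound 2 and well below that of compound 1.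

Compound 4, `ClCc1ccccc1Cn1cnc2nc(Cl)nc(Cl)c21`, has not yet been measured. It stands to compound 3 as compound 2 stands to compound 1: chloro in place of hydrogen on an aromatic carbon, at a place described in the same words as the earlier one, so this is the same change. Going by the values given here, the expectation for compound 4 rests on that one measured step, because a 12-fold lower number from compound 1 to compound 2 (1.08 log units; beyond the scatter) is the only precedent. The step expected from compound 3 is a 9.2-fold lower number from compound 3 to compound 4 (0.96 log units; beyond the scatter), taken somewhat more cautiously than the precedent, since a single pair carries limited weight. Compound 4 is therefore estimated at 300 nM in this assay, with a plausible range from 100 nM to 1000 nM.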

Compound 4, concentration for 50% growth inhibition: 2750 nM
For compound 4 the middle estimate is 9.2-fold (0.96 log units) below the measured one; the measured number lies above the stated range.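

In this assay, chloro in place of hydrogen on the aromatic carbon between two ring nitrogen atoms gives no change at the digits printed from compound 3 to compound 4 (within the scatter). The change therefore does not carry over in size from the core of compound 1 to the core of compound 3, and the two steps differ by more than their scatter: the same change on two cores in this assay, a 12-fold lower number (1.08 log units; beyond the scatter) from compound 1 to compound 2 and no change at the digits printed (within the scatter) from compound 3 to compound 4, 12-fold (1.08 log units) apart, beyond the scatter of two such steps. This shows that, for these two pairs, the result of the change depends on the core, but two pairs in one cell assay give no reason for the difference and no rule for any further core.

The compounds shown leave open whether another group on that same aromatic carbon, such as an amine or a methoxy group, would follow either step. They also leave open whether a hydroxymethyl group in place of the chloromethyl group would keep the same difference between the two cores.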